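A few compounds are considered here, and "the series" means these few. Any claim that something is new, unique, unknown or untested is made for them only; others in the source may bear on it.

Measured compounds and their values:

Compound 1, `COc1ccc2c(c1)c(-c1cc(C(F)(F)F)ccn1)cn2S(=O)(=O)c1ccc(C)cc1`: 15.6%
Compound 2, `COc1ccc2c(c1)c(-c1cc(C(F)(F)F)cc(-c3cn(S(=O)(=O)c4ccc(C)cc4)c4ccc(OC)cc34)n1)cn2S(=O)(=O)c1ccc(C)cc1`: 13.8%

Both measured compounds were tested in a functional assay on P388 cells (Mus musculus) for inhibition, tested at 100 uM; a higher number here means a stronger effect of the compound at the concentration tested, a lower number a weaker effect. In this assay compound 1 gives 15.6%. Compound 2 gives 13.8% in this assay. The two numbers lie within the usual scatter of each other, so nothing separates compound 1 from compound 2 on these data; both show only weak inhibition at the concentration tested.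

Compound 3, `Cc1ccc(S(=O)(=O)n2cc(-c3cc(C(F)(F)F)ccn3)c3cc(OCc4ccccc4)ccc32)cc1`, has not yet been measured. It differs from compound 1 in one place: phenyl in place of hydrogen on a saturated chain carbon bound to an oxygen on an aromatic ring. Within the data shown here, no measured pair of compounds shows this change, so there is no step to compare it with. Among the measured compounds shown here, the only guide is that the two measured compounds, which differ a great deal in size, give almost the same weak inhibition, and a change at the methoxy group in compound 1 gives no reason to expect more.

The step from compound 1 to compound 3 is therefore expected to be small, a number 2.4 percentage points higher from compound 1 to compound 3 (within the scatter), in this assay, with no clear direction beyond the scatter. Compound 3 is expected to give about 18%, somewhere between 5% and 40%.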

Compound 3, a percentage reported as inhibition, at one concentration (the size of the read-out at that concentration, not a potency): 2.2%
Beside the measured number, compound 3's estimate is 15.8 percentage points above it, outside the stated range (below it).
By their numbers in this assay, from the lowest: compound 3; then compounds 2 and 1 (each within the scatter of the next).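

In this assay the methoxy group of compound 1 proves to be a place where a change can be seen: going from methoxy to benzyloxy gives a number 13.4 percentage points lower from compound 1 to compound 3 (beyond the scatter) and so moves the read-out down, not up. Among these compounds, compound 1 and compound 2 differ in more than one place and could say nothing about this position, so this is the first single change that can be read on its own. Nothing in the data shown accounts for the drop, which stands as an observation without an explanation.

With only one replacement shown at this position, it remains open whether any group larger than methoxy lowers the read-out or whether the phenyl itself matters, which an ethoxy group, a longer chain ending in phenyl, or a chain carrying an amine or a carboxylic acid could help to separate. These read-outs also come from a single concentration, so they show the size of the effect at that concentration and leave the potency of all three compounds unknown.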